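A few compounds are considered here, and "the series" means these few. Any claim that something is new, unique, unknown or untested is made for them only; others in the source may bear on it.

Of the compounds shown here, three on a shared core have been read in a toxicity assay on Vero cells (Chlorocebus sabaeus) for cytotoxicity; on this read-out higher numbers stand for lower toxicity in this test and lower numbers for higher toxicity in this test. Compound 3 `COc1nc(-c2ccc(C#N)cc2)ccc1[C@@H](c1ccccc1)[C@@](O)(CCN(C)C)c1cccc2ccccc12` gives > 50 ug/mL, which is a limit of the assay and not a number. Compound 2 `COc1nc(-c2ccc(OC(F)(F)F)cc2)ccc1[C@@H](c1ccccc1)[C@@](O)(CCN(C)C)c1cccc2ccccc12` gives > 50 ug/mL, which is likewise a limit. These two make up (the limit of > 50 ug/mL in this assay, at which 2 of the 3 values shown sit). Among the measured compounds shown here, compound 1 `COc1nc(-c2ccsc2)ccc1[C@@H](c1ccccc1)[C@@](O)(CCN(C)C)c1cccc2ccccc12`, which carries thiophen-3-yl, is the only one with a true number, at 24.4 ug/mL.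

Compound 4 `COc1nc(-c2cnsc2)ccc1[C@@H](c1ccccc1)[C@@](O)(CCN(C)C)c1cccc2ccccc12` puts 1,2-thiazol-4-yl in place of the 4-cyanophenyl of compound 3, on an aromatic carbon next to the ring nitrogen: 1,2-thiazol-4-yl in place of 4-cyanophenyl on an aromatic carbon. For the measured compounds named here, two measured steps bear on this change, an at least 2.0-fold higher number from compound 1 to compound 3 (0.31 log units; beyond the scatter) and an at least 2.0-fold higher number from compound 1 to compound 2 (0.31 log units; beyond the scatter), and both lie beyond the scatter. The remaining step, a step that the two limits leave unreadable from compound 2 to compound 3, gives no size to work with.

Going by the values given here, no measured compound carries 1,2-thiazol-4-yl, so the closest guide is the thiophen-3-yl of compound 1 at 24.4 ug/mL. On that basis the change should roughly run the step to compound 3 backwards, modest in size, toward a lower number and so higher toxicity in this assay. The expected result is an at least 1.6-fold lower number from compound 3 to compound 4 (0.22 log units; that floor lies within the scatter). For compound 4 the estimated value is 30 ug/mL, with an expected range from 14 ug/mL to 65 ug/mL.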

Compound 4, half-maximal cytotoxic concentration: 26.3 ug/mL
Compound 4: middle estimate off by 1.1-fold (0.06 log units), on the high side; measured number inside the range.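

In this assay, the 1,2-thiazol-4-yl group on this aromatic carbon next to the ring nitrogen cannot be told apart from the thiophen-3-yl group, the step being a 1.1-fold higher number from compound 1 to compound 4 (0.03 log units; within the scatter). Set against the two substituted phenyl groups, the new group gives an at least 1.9-fold lower number from compound 3 to compound 4 (0.27 log units; that floor lies within the scatter) and an at least 1.9-fold lower number from compound 2 to compound 4 (0.27 log units; that floor lies within the scatter), so each floor alone does not establish a real difference, although the true gaps could be larger. Across the four compounds, the two five-membered rings now both give true numbers, while the two substituted phenyl groups both stay at a limit: the limit of > 50 ug/mL in this assay, at which 2 of the 4 values shown sit.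

The compounds shown leave open the true numbers of compound 2 and compound 3, so the step between them cannot be read. They also leave open whether the split follows the ring or the substituent on it, which an unsubstituted phenyl or a phenyl carrying an amine at this position could help to separate.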